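A few compounds are considered here, and "the series" means these few. Any claim that something is new, unique, unknown or untested is made for them only; others in the source may bear on it.

Compound 1 `COC(=O)C1=C(C)NC(=O)N(C(=O)NCCCN2CCN(c3ccccc3OC)CC2)C1c1ccc(F)c(F)c1` carries a 2-methoxyphenyl on the ring nitrogen of its piperazine-like six-membered ring and in an assay on liver for binding affinity to Alpha-1B adrenergic receptor (Homo sapiens), using microsomes (a higher number here means a weaker inhibitor, a lower number a stronger inhibitor), compound 1 gives 18 nM. Among the three measured compounds this is the second highest number. Compound 2 `COC(=O)C1=C(C)NC(=O)N(C(=O)NCCCN2CCN(c3ccccc3O)CC2)C1c1ccc(F)c(F)c1` gives 16 nM in this assay, and the step of a 1.1-fold lower number from compound 1 to compound 2 (0.05 log units; within the scatter) lies within the scatter, so these two compounds cannot be told apart. Compound 3 `CCC1=C(C(N)=O)C(c2ccc(F)cc2F)N(C(=O)NCCCN2CCN(c3ccccc3C(N)=O)CC2)C(=O)N1` differs from compound 1 in several places at once, and compound 3 gives 720 nM, a far weaker result.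

Compound 4 `COC(=O)C1=C(C)NC(=O)N(C(=O)NCCCN2CCN(c3ccc(Cl)cc3)CC2)C1c1ccc(F)c(F)c1` takes the same core as compound 1 but changes the aromatic group on the ring nitrogen: 4-chlorophenyl in place of 2-methoxyphenyl on an amine nitrogen in a ring. For the measured compounds named here, the only single-step comparison available, the step of a 1.1-fold lower number from compound 1 to compound 2 (0.05 log units; within the scatter), touches the same aromatic ring and shows that changing its oxygen substituent left the number within the scatter. Going by the values given here, replacing the whole ring with 4-chlorophenyl goes further than that step, and no measured pair covers such a swap; compound 3 changes too much elsewhere to help. The expectation is therefore a modest change, if any, with a step of a 1.7-fold higher number from compound 1 to compound 4 (0.22 log units; within the scatter) expected from compound 1 to compound 4. Compound 4 is estimated at 30 nM, with a likely range from 8 nM to 110 nM.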

Compound 4, inhibition constant: 17 nM
Beside the measured number, compound 4's estimate is 1.8-fold (0.25 log units) above it; low and high end bracket the measured number.
By their numbers in this assay, from the lowest: compounds 2, 4 and 1 (each within the scatter of the next); then compound 3.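

In this assay, the step of a 1.1-fold lower number from compound 1 to compound 4 (0.02 log units; within the scatter) shows that this position accepts more than a small edit: the whole 2-methoxyphenyl on the amine nitrogen in the ring gives way to 4-chlorophenyl, and the two compounds still cannot be told apart. Compound 1 and compound 2 had only shown that the oxygen substituent could be altered on a ring that stayed in the same place, whereas here the substituent, its place on the aromatic ring and the hydrogen-bond acceptor count all differ, with one acceptor in 2-methoxyphenyl and none in 4-chlorophenyl; the step of a 1.1-fold higher number from compound 2 to compound 4 (0.03 log units; within the scatter) gives the same reading against 2-hydroxyphenyl. No measurement on hand explains why these three groups cannot be separated in this assay.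

On these data alone, it remains open whether an unsubstituted phenyl, a pyridine ring or a simple methyl on this nitrogen would also leave the number unmoved, and so whether an aromatic ring is needed there at all. Compound 3 differs from the others in several places at once, so its much higher number cannot be pinned on any single change.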